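Removing the Acetyl Group from Compound 2

The source may report more compounds than this note shows. Statements on the series, on what has been measured and on what is new or still open speak of the compounds shown alone.

Compound 1, `COc1cc2ccc(=O)oc2cc1OCCOc1no[n+]([O-])c1S(=O)(=O)c1ccccc1`: 3540 nM
Compound 2, `COc1cc2cc(NC(C)=O)c(=O)oc2cc1OCCOc1no[n+]([O-])c1S(=O)(=O)c1ccccc1`: 6890 nM
Compound 3, `COc1cc2cc(NC(C)=O)c(=O)oc2cc1OCCCOc1no[n+]([O-])c1S(=O)(=O)c1ccccc1`: 2400 nM

Of the compounds shown here, three have been measured in a functional assay on MCF7 cells (Homo sapiens) for inhibition, read by MTT assay, with a stated time of 48 h; on this read-out lower numbers stand for stronger inhibition and higher numbers for weaker inhibition. Compound 2 gives the highest of the three numbers in this assay. Compound 1 lies nearest to it, and the step of a 1.9-fold higher number from compound 1 to compound 2 (0.29 log units; within the scatter) is within the scatter. Among the compounds with values here, compound 3 lies furthest from compound 2, and in this assay compound 3 gives 2400 nM, a number that is lower than that of compound 2 by more than the scatter; no single-point step joins these two compounds, so only their two values can be compared.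

Compound 4, `COc1cc2cc(N)c(=O)oc2cc1OCCOc1no[n+]([O-])c1S(=O)(=O)c1ccccc1`, has not yet been measured. It differs from compound 2 in one place: hydrogen in place of acetyl on a nitrogen on an aromatic ring. Within the data shown here, no measured step describes exactly this change. Among the measured compounds shown here, the only step that touches the same nitrogen is a 1.9-fold higher number from compound 1 to compound 2 (0.29 log units; within the scatter), in which the whole acetamido group entered in place of hydrogen, and that step stayed within the scatter. Since adding the acetamido group moved the number only slightly, cutting the acetyl back off is expected to move it slightly as well, in either direction, with no step beyond the scatter: a 1.4-fold lower number from compound 2 to compound 4 (0.14 log units; within the scatter) is the expected outcome. Compound 4 is therefore estimated at 5000 nM in this assay, with a range from 1500 nM to 16000 nM.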

Compound 4, half-maximal inhibitory concentration: 2770 nM
Beside the measured number, compound 4's estimate is 1.8-fold (0.26 log units) above it; measured number inside the range.
By their numbers in this assay, from the lowest: compounds 3, 4, 1 and 2 (each within the scatter of the next, the first and the last beyond it).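

In this assay, within the data shown here, taking the acetyl off the nitrogen gives the first step at this position that passes the scatter, namely a 2.5-fold lower number from compound 2 to compound 4 (0.40 log units; beyond the scatter). The earlier step of a 1.9-fold higher number from compound 1 to compound 2 (0.29 log units; within the scatter) could not show this, whereas the amino group of compound 4 now separates the two parts of the acetamido group: the step of a 1.3-fold lower number from compound 1 to compound 4 (0.11 log units; within the scatter) leaves amino and hydrogen on the aromatic carbon unresolved, so among these compounds only the acetamido compound, compound 2, stands apart from compound 4, and it does so only modestly. Nothing measured here explains why the acetyl on this nitrogen should make this difference.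

On these data alone, it remains open whether another group on this nitrogen, such as a formyl, a benzoyl or a methyl, would give a number close to that of the acetamido compound or close to that of the amino compound. It also remains open whether the change from acetamido to amino would give a similar step on the longer chain of compound 3, which carries the acetamido group and has no amino partner among these compounds.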